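Hydroxy to amino swaps on a stilbene-type series

The compounds below may be only part of what the source reports. "The series", "measured", "known", "first", "only" and "open" are said of these compounds alone.

Measured compounds:
compound 1 `Oc1cccc(/C=C/c2ccccc2O)c1` — 18 ug/mL
compound 2 `Oc1ccc(/C=C/c2cccc(O)c2)cc1` — 1.1 ug/mL
compound 3 `Nc1ccccc1/C=C/c1cccc(O)c1` — 20 ug/mL

All three were run in an ADME assay on HEK293 cells (Homo sapiens) for inhibition, read by MTT assay, with a stated time of 2 days; a higher number here means a weaker inhibitor, a lower number a stronger inhibitor. Compound 2 gives the lowest number of the set; the two others lie well beyond the scatter from it. The difference between the core of compound 1 and the core of compound 2 is not broken down here.

One change has already been measured once: amino in place of hydroxy on an aromatic carbon, giving a 1.1-fold higher number from compound 1 to compound 3 (0.05 log units; within the scatter). The unmeasured compound 4 `Nc1cccc(/C=C/c2ccc(O)cc2)c1` carries the same kind of change relative to compound 2: amino in place of hydroxy on an aromatic carbon. The two differ in where the change sits, ortho to the nine-heavy-atom group in the first case and meta to it in the second.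

Since the measured step is within the scatter, the expected step is a 1.4-fold higher number from compound 2 to compound 4 (0.13 log units; within the scatter), close to flat, resting on compound 1 and compound 3 only. Compound 4 is therefore estimated at 1.5 ug/mL, with a range of 0.6 ug/mL to 4 ug/mL.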

Compound 4, half-maximal inhibitory concentration: 7 ug/mL
Compound 4: the middle estimate sits 4.7-fold (0.67 log units) below what was measured; the whole stated range lies below it.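

In this assay amino in place of hydroxy on an aromatic carbon gives a 6.4-fold higher number from compound 2 to compound 4 (0.80 log units; beyond the scatter) and so does not stay flat on this core. The change does not carry over unaltered between the two cores: the same change on two cores in this assay, a 1.1-fold higher number (0.05 log units; within the scatter) from compound 1 to compound 3 and a 6.4-fold higher number (0.80 log units; beyond the scatter) from compound 2 to compound 4, 5.7-fold (0.76 log units) apart, beyond the scatter of two such steps. Within the data shown here, with only two pairs, and with both the core and the place of the change differing between them, this gives no rule for other cores and does not show which difference matters.

Open, from the compounds shown here alone, is whether a methoxy group or an acetamide in the same place on the core of compound 2 would track hydroxy or amino. Also open, going by these compounds, is how amino would read at other places on that core.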